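A few compounds are considered here, and "the series" means these few. Any claim that something is new, unique, unknown or untested is made for them only; others in the source may bear on it.

Compound 1 `CCCCCCCCOC(=O)CCC(=O)N1CCN(CCCOc2cc3c(Nc4ccc(F)c(Cl)c4)ncnc3cc2OC)CC1` and compound 2 `CCCCCCCCCCCOC(=O)CCC(=O)N1CCN(CCCOc2cc3c(Nc4ccc(F)c(Cl)c4)ncnc3cc2OC)CC1` share one core and differ in one place only. In a functional assay on A549 cells (Homo sapiens) for cytotoxicity, read by MTT assay, with a stated time of 24 h, tested at 10 uM (on this read-out higher numbers stand for a weaker effect at the one concentration tested and lower numbers for a stronger effect), compound 1 gives 87.3%, and compound 2 gives 93.4%. Compound 2 thus holds the highest of the two numbers, but the step of a number 6.1 percentage points higher from compound 1 to compound 2 (within the scatter) lies within the scatter. Compound 3 `CCCCCCCCCCCCCCOC(=O)CCC(=O)N1CCN(CCCOc2cc3c(Nc4ccc(F)c(Cl)c4)ncnc3cc2OC)CC1` carries the same kind of change once more: propyl in place of hydrogen on a saturated chain carbon, ten or more bonds along the chain from an oxygen next to a carbonyl group. Among the compounds with values here, the only step that bears on it, a number 6.1 percentage points higher from compound 1 to compound 2 (within the scatter), stayed within the scatter, so no step beyond the scatter is expected in this assay. Compound 3 is therefore estimated at 93%, between 80% and 100%, an expected step of a number 0.4 percentage points lower from compound 2 to compound 3 (within the scatter).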

Compound 3, a percentage reported as activity, at one concentration (the size of the read-out at that concentration, not a potency): 100%
Beside the measured number, compound 3's estimate is 7 percentage points below it, within the range that was stated.
By their numbers in this assay, from the lowest: compounds 1, 2 and 3 (each within the scatter of the next, the first and the last beyond it).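

In this assay, propyl in place of hydrogen on a saturated chain carbon, ten or more bonds along the chain from an oxygen next to a carbonyl group, gives a number 6.6 percentage points higher from compound 2 to compound 3 (within the scatter), so this change alone again does not separate two compounds. Hexyl in place of hydrogen, eight bonds along the chain from that oxygen, gives a number 12.7 percentage points higher from compound 1 to compound 3 (beyond the scatter), the only step here beyond the scatter, modest in size and towards a weaker effect at the one concentration tested. Nothing available explains this step. Going by these compounds, how a longer chain, or a chain ending in an amine or a carboxylic acid, would read remains open.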